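Replacing nitro with chloro in compound 1

The source may hold more compounds than are shown below. What is called first, only, known or untested is meant among the compounds shown, and "the series" means these compounds.

Measured so far in a functional assay on the whole organism (strain albino) with Mus musculus as the target, with a stated time of 0.5 h; on this read-out lower numbers stand for an effect already at smaller amounts and higher numbers for an effect only at larger amounts of compound:
- compound 1 (`COc1ccc(C2CC(Nc3nc4ccc([N+](=O)[O-])cc4s3)=NN2C(C)=O)cc1`) gives 149 umol/kg
- compound 2 (`CC(=O)N1N=C(Nc2nc3ccc([N+](=O)[O-])cc3s2)CC1c1ccc(Cl)cc1`) gives 138 umol/kg

Compound 1 has a single measured neighbour, and the two stand level: a 1.1-fold lower number from compound 1 to compound 2 (0.03 log units; within the scatter) is all that separates them. The next compound is compound 3 (`COc1ccc(C2CC(Nc3nc4ccc(Cl)cc4s3)=NN2C(C)=O)cc1`), which differs from compound 1 by chloro in place of nitro on an aromatic carbon. Within the data shown here, only that one measured step bears on this change. Among the measured compounds shown here, it also brings in chloro, but there chloro replaces methoxy at another place, so it is a weak guide, and no measured pair shows the loss of nitro. In this assay no step beyond the scatter is therefore expected, in either direction, though with wide uncertainty. The expected step is a 1.1-fold lower number from compound 1 to compound 3 (0.03 log units; within the scatter) and no more than that. For compound 3 the estimated value is 140 umol/kg, with an expected range from 60 umol/kg to 330 umol/kg.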

Compound 3, dose for half-maximal effect: 97.3 umol/kg
The estimate for compound 3 lay 1.4-fold (0.16 log units) above the measured number, within the range that was stated.
By their numbers in this assay, from the lowest: compounds 3, 2 and 1 (each within the scatter of the next).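

In this assay, among these compounds, the exchange of nitro for chloro comes to a 1.5-fold lower number from compound 1 to compound 3 (0.19 log units; within the scatter), so this position on the six-membered aromatic ring, which had carried only nitro in the earlier compounds, also accepts a smaller group without hydrogen-bond acceptors. For this pair, nitro is therefore not required for an effect in the whole animal, and the earlier step at the other place gave no view of this. Nothing available explains why the two groups stand level here.

From the compounds shown here alone, whether an amine, a carboxylic acid or a plain hydrogen at this position would also stand level with nitro and chloro remains open. So does whether chloro here would give the same result when methoxy on the other aromatic ring is also replaced by chloro.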